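A few compounds are considered here, and "the series" means these few. Any claim that something is new, unique, unknown or untested is made for them only; others in the source may bear on it.

- Compound 1 `COc1ccc(/N=N\c2ccc(F)c(C(=O)Nc3cnc4[nH]nc(OC)c4c3)c2F)cc1`: > 24 h (a limit)
- Compound 2 `COc1n[nH]c2ncc(NC(=O)c3c(F)ccc(/N=N\c4ccccc4F)c3F)cc12`: 5 h

In an unclassified assay for pharmacokinetics, read by NMR, at pH 7.5, tested at 2 mg/mL (on this read-out lower numbers stand for a shorter-lived compound and higher numbers for a longer-lived compound), compound 1 gives only a limit, > 24 h. Among the measured compounds shown here, compound 2 gives 5 h, the only actual number so far, and it stands on the low side of this pair. Compound 3 `COc1n[nH]c2ncc(NC(=O)c3c(F)ccc(/N=N\c4ccc(C)cc4)c3F)cc12` departs from compound 2 by a single change: 4-methylphenyl in place of 2-fluorophenyl on a double-bonded nitrogen. In short, 4-methylphenyl stands in place of 2-fluorophenyl on a double-bonded nitrogen. For the measured compounds named here, one measured step bears on this, at the same place: an at least 4.8-fold lower number from compound 1 to compound 2 (0.68 log units; beyond the scatter), beyond the scatter, with 2-fluorophenyl replacing 4-methoxyphenyl. Reversing that swap is only partly what compound 3 does, since its 4-methylphenyl is not the 4-methoxyphenyl of compound 1, so a rise of moderate size is expected, and the size is uncertain. The expected move is a 3.6-fold higher number from compound 2 to compound 3 (0.56 log units; beyond the scatter). Compound 3 is estimated at 18 h, with an expected range of 7 h to 50 h.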

Compound 3, half-life: > 24 h
Compound 3 ended at the assay's limit; the forecaster's own chance of this, stated with the estimate: 40%; middle value at least 1.3-fold (0.12 log units) away from the limit.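

At this place on a double-bonded nitrogen, this assay now gives an at least 4.8-fold higher number from compound 2 to compound 3 (0.68 log units; beyond the scatter), so the earlier drop with 2-fluorophenyl does not depend on the loss of methoxy alone: 4-methylphenyl, which has no oxygen, also restores a long-lived compound. Among the compounds shown, only compound 2, with 2-fluorophenyl, gives a number rather than a limit. The values of compound 1 and compound 3 are both limits, so the step between them cannot be read, and methyl and methoxy cannot be ranked here: the limit of > 24 h in this assay, at which 2 of the 3 values shown sit.

As far as these compounds go, it remains open whether the shorter life of compound 2 goes with its fluorine or with the lack of a 4-methyl or 4-methoxy group. Unsubstituted phenyl or 4-aminophenyl at this place would bear on that, and how far compound 1 and compound 3 lie beyond the limit also stays unknown.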